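Swapping the halogen on the anilide ring: chloro to fluoro

The source may report more compounds than this note shows. Statements on the series, on what has been measured and on what is new or still open speak of the compounds shown alone.

Compounds with measurements in hand:
compound 1, `CC(C)Cc1ccc(NS(=O)(=O)c2ccc(N3CCNC3=O)cc2)cc1`: > 1000 nM
compound 2, `O=C1NCCN1c1ccc(S(=O)(=O)Nc2cccc(Cl)c2)cc1`: 55 nM
compound 3, `O=C1NCCN1c1ccc(S(=O)(=O)Nc2ccc(Cl)cc2)cc1`: 220 nM

In a functional assay on HT-29 cells (Homo sapiens) for antiproliferative activity, read by sulforhodamine B assay, with a stated time of 48 h (a higher number here means a weaker inhibitor, a lower number a stronger inhibitor), compound 1 gives only a limit, > 1000 nM, not a number (the limit of > 1000 nM in this assay, at which 1 of the 3 values shown sits). Of the two numbers that were obtained, compound 3 stands highest, with compound 2 at a clearly lower number; the gap is a 4.0-fold higher number from compound 2 to compound 3 (0.60 log units; beyond the scatter), which came from the move of the chloro group to another position on the anilide ring. The other measured step, an at least 4.5-fold lower number from compound 1 to compound 3 (0.65 log units; beyond the scatter), shows that the chloro group itself is far better here than an isobutyl group at the same place.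

Compound 4, `O=C1NCCN1c1ccc(S(=O)(=O)Nc2ccc(F)cc2)cc1`, has not yet been tested in this assay. It differs from compound 3 in one point: fluoro in place of chloro on an aromatic carbon. Within the data shown here, no measured step in this set exchanges one halogen for another, so neither step speaks directly to this change. The two steps show the halogen and its position matter, but give no direction for a chloro-to-fluoro swap. Compound 4 is therefore expected to land close to compound 3, with a wide range, the expected step being a 1.6-fold higher number from compound 3 to compound 4 (0.20 log units; within the scatter). The estimate for compound 4 is 350 nM, spanning from 120 nM to 1000 nM.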

Compound 4, half-maximal inhibitory concentration: 370 nM
For compound 4 the middle estimate is 1.1-fold (0.02 log units) below the measured one; the measured number falls inside the stated range.
By their numbers in this assay, from the lowest: compound 2; then compounds 3 and 4 (each within the scatter of the next). At a limit, above all of these: compound 1.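

In this assay, fluoro in place of chloro at this place, para to a large group, gives a 1.7-fold higher number from compound 3 to compound 4 (0.23 log units; within the scatter), so compounds 3 and 4 cannot be told apart, and the kind of halogen makes no clear difference here; the halogen's place on the ring counts for more, since the change from 3-chlorophenyl to 4-fluorophenyl gives a 6.7-fold higher number from compound 2 to compound 4 (0.83 log units; beyond the scatter). Fluoro also does better than isobutyl at this place, as chloro did, with an at least 2.7-fold lower number from compound 1 to compound 4 (0.43 log units; beyond the scatter). Compound 1 gives a limit of the assay and not a number, so that step has only a lower bound: the limit of > 1000 nM in this assay, at which 1 of the 4 values shown sits.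

Open, from the compounds shown here alone, is whether fluoro would behave like chloro at the ring place it holds in compound 2, or whether a larger halogen such as bromo would fit the same picture at either place. The compounds shown also do not tell how a group of another kind, such as an amine or a carboxylic acid, would fare on this ring, since chloro, fluoro and isobutyl are the only groups compared here.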